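Shortening propyl to ethyl in compound 2

This account rests on a few compounds, and the source may have more. Where it says the series, first, only, none or still open, it means among the compounds named here.

Compound 1 `CC(C)C[C@H](NC(=O)CNC(=O)N1C/C(=C\c2ccc(F)cc2)C(=O)/C(=C/c2ccc(F)cc2)C1)B1OC(C)(C)C(C)(C)O1` gives 375 nM in a functional assay on HCT-116 cells (Homo sapiens) for antiproliferative activity, read by MTT assay, with a stated time of 72 h; a lower number here means a stronger inhibitor, a higher number a weaker inhibitor
Compound 2 `CCC[C@H](NC(=O)N1C/C(=C\c2ccc(F)cc2)C(=O)/C(=C/c2ccc(F)cc2)C1)B1OC(C)(C)C(C)(C)O1` gives 785 nM in this assay

Of these two, compound 2 (785 nM) has the higher number, and its gap to compound 1 lies beyond the usual scatter. Compound 3 (`CC[C@H](NC(=O)N1C/C(=C\c2ccc(F)cc2)C(=O)/C(=C/c2ccc(F)cc2)C1)B1OC(C)(C)C(C)(C)O1`) carries ethyl where compound 2 carries propyl (hydrogen in place of methyl on a saturated chain carbon, three bonds along the chain from an amide-type nitrogen and a boron atom), hydrogen in place of methyl on a saturated chain carbon, three bonds along the chain from an amide-type nitrogen and a boron atom. Among the measured compounds shown here, no measured pair shows this change alone, so no step beyond the scatter is expected in this assay. An estimated 1.1-fold higher number from compound 2 to compound 3 (0.03 log units; within the scatter) would stay within that scatter. For compound 3 the estimated value is 850 nM within a range of 400 nM to 1800 nM in this assay.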

Compound 3, half-maximal inhibitory concentration: 876 nM
The estimate for compound 3 lay 1.0-fold (0.01 log units) below the measured number, and the stated range covers the measured number.
By their numbers in this assay, from the lowest: compound 1; then compounds 2 and 3 (each within the scatter of the next).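

In this assay the change from propyl to ethyl on this saturated chain carbon gives a 1.1-fold higher number from compound 2 to compound 3 (0.05 log units; within the scatter) and so stays within the scatter. Among the compounds shown here, this is the first comparison in which only one place differs, and it shows that hydrogen in place of methyl here leaves the antiproliferative reading unmoved for this pair. No measurement shown accounts for this result.

The compounds shown leave open whether a longer chain such as butyl, or methyl in place of ethyl, would hold this level. On these data alone, whether an amine or a carboxylic acid at this carbon would do so also remains open.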